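The source may hold more compounds than are shown below. What is called first, only, known or untested is meant among the compounds shown, and "the series" means these compounds.

Working notes on the series. Compound 1 `Cc1nc(Nc2ccccc2)sc1C(=O)/C=C/c1ccc(Cl)cc1` in a functional assay on NCI-H460 cells (Homo sapiens) for cytotoxicity, read by MTT assay (on this read-out higher numbers stand for weaker inhibition and lower numbers for stronger inhibition), gives only a limit, > 25000 nM. Compound 2 `Cc1ccccc1Nc1nc(C)c(C(=O)/C=C/c2ccc(Cl)cc2)s1` in this assay likewise gives only a limit, > 25000 nM. Compound 3 `Cc1nc(Nc2cccc(Cl)c2)sc1C(=O)/C=C/c1ccc(Cl)cc1` in this assay also gives only a limit, > 25000 nM. All three values sit at the same limit (the limit of > 25000 nM in this assay, at which 3 of the 3 values shown sit), and for that reason the steps a step that the two limits leave unreadable from compound 1 to compound 2, a step that the two limits leave unreadable from compound 1 to compound 3 and a step that the two limits leave unreadable from compound 2 to compound 3 cannot be read in size. Compound 3 therefore stands at the limit, with no number that separates it from the other two.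

Compound 4 `Cc1nc(Nc2ccc(Cl)c(Cl)c2)sc1C(=O)/C=C/c1ccc(Cl)cc1` differs from compound 3 by chloro in place of hydrogen on an aromatic carbon. Among the measured compounds shown here, the only measured step of the same kind is a step that the two limits leave unreadable from compound 1 to compound 3, which is unreadable because both ends sit at the limit (the limit of > 25000 nM in this assay, at which 3 of the 3 values shown sit). For the measured compounds named here, no measured step gives a readable size in either direction, so nothing in this assay points to a change beyond the scatter. Compound 4 is accordingly expected to remain at the limit, with an estimate of 40000 nM spanning 15000 nM to 150000 nM. The expected step that the limit leaves unreadable from compound 3 to compound 4 is thus no more than the scatter.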

Compound 4, half-maximal inhibitory concentration: > 25000 nM
Compound 4: no number, only a limit; the forecaster's own chance of this, stated with the estimate: 85%; the middle value lies beyond the limit too.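

In this assay compound 4 gives only a limit, > 25000 nM. Its steps from compound 1, compound 2 and compound 3 therefore cannot be read in size: the limit of > 25000 nM in this assay, at which 4 of the 4 values shown sit.

The compounds shown leave open whether any change to the group on the nitrogen alters the read-out in this assay.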